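Cytotoxicity readings across the series, one analogue pending

This account rests on a few compounds, and the source may have more. Where it says the series, first, only, none or still open, it means among the compounds named here.

compound 1 `CC(C)N(Cc1cccc(OCCCCCC(=O)O)c1)C(=O)c1ccccc1` — an ADME assay on Raji cells (Homo sapiens) for cytotoxicity, read by CellTiter-Glo and resazurin assay, with a stated time of 72 h; on this read-out higher numbers stand for an effect only at larger amounts of compound and lower numbers for an effect already at smaller amounts: > 26000 nM
compound 2 `CCOC(=O)CCCCCOc1cccc(CN(C(=O)c2ccc(-c3cccc(N(C)C)c3)cc2)C(C)C)c1` — this assay : > 26000 nM

In this assay compound 1 gives > 26000 nM, which is a limit of the assay and not a number. Compound 2 likewise gives only a limit, > 26000 nM. For the measured compounds named here, compound 2 therefore stands at the top end of what was measured, together with the only other value shown, as the limit of > 26000 nM in this assay, at which 2 of the 2 values shown sit, records. Compound 3 `CCOC(=O)CCCCCOc1cccc(CN(C(=O)c2ccc(-c3cccc(-c4nnc(C)o4)c3)cc2)C(C)C)c1` is the unmeasured analogue; it differs from compound 2 by the change (5-methyl-1,3,4-oxadiazol-2-yl in place of dimethylamino on an aromatic carbon). Going by the values given here, no step between measured compounds is available to size this change. Because the limit of > 26000 nM in this assay, at which 2 of the 2 values shown sit, puts every shown value at the limit, the step expected is a number no higher from compound 2 to compound 3 (the limit leaves the size open), none beyond the scatter, with another limit the most probable outcome. Compound 3 is thus estimated at 26000 nM, in the range 13000 nM to 60000 nM.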

Compound 3, half-maximal effective concentration: > 26000 nM
Compound 3: a limit, no number (the forecaster's own chance of this, stated with the estimate: 80%); the middle value sits exactly at the limit.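

No step can be read from compound 2 to compound 3, as both give only limits in this assay: the limit of > 26000 nM in this assay, at which 3 of the 3 values shown sit.

Still open, going by these compounds, is the concentration at which compound 1, compound 2 or compound 3 would reach a half-maximal effect in this assay, and whether 5-methyl-1,3,4-oxadiazol-2-yl in place of dimethylamino shifts it.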